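The compounds below may be only part of what the source reports. "The series", "measured", "known", "first", "only" and "open" are said of these compounds alone.

Measured in a functional assay on CHO/Galpha16 cells for antagonist activity at prostaglandin E2 receptor EP4 subtype (Homo sapiens), read by calcium flux, with a stated time of 15 min; on this read-out lower numbers stand for stronger inhibition and higher numbers for weaker inhibition:
compound 1, `COc1ccc(Cc2sc3c(c2C(=O)N[C@@H](C)c2ccc(C(=O)O)cc2)CCOC3)cc1`, gives 2.1 nM;
compound 2, `CCC1CCc2c(sc(CCc3ccc(F)cc3)c2C(=O)N[C@@H](C)c2ccc(C(=O)O)cc2)C1`, gives 649 nM.

Of these two numbers, compound 1 stands lowest, and compound 2 sits far above it, a gap well beyond the scatter. Compound 3, `C[C@H](NC(=O)c1c(C#Cc2ccc(F)cc2)sc2c1CCOC2)c1ccc(C(=O)O)cc1`, differs from compound 1 in one place: 2-(4-fluorophenyl)ethynyl in place of 4-methoxybenzyl on an aromatic carbon. Going by the values given here, no measured pair shows this change on its own, so the step must be guessed from the structures alone. In this assay, the step from compound 1 to compound 3 is expected to be a modest loss, somewhat beyond the scatter: a 4.8-fold higher number from compound 1 to compound 3 (0.68 log units; beyond the scatter). Compound 3 is therefore estimated at 10 nM, within 2 nM to 60 nM.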

Compound 3, half-maximal inhibitory concentration: 15.8 nM
The estimate for compound 3 lay 1.6-fold (0.20 log units) below the measured number; the measured number falls inside the stated range.
By their numbers in this assay, from the lowest: compound 1; then compound 3; then compound 2.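

Next to the ring sulfur of the shared core, 2-(4-fluorophenyl)ethynyl can replace 4-methoxybenzyl at a modest cost: in this assay the swap gives a 7.5-fold higher number from compound 1 to compound 3 (0.88 log units; beyond the scatter). Both groups carry the same count of heavy atoms and one six-membered aromatic ring of carbon only, so the difference lies in how that ring is attached and what it bears. Nothing measured here explains the loss. The compounds shown cannot separate the triple bond from the swap of methoxy for fluorine, which 4-fluorobenzyl could do. From the compounds shown here alone, how an amine or a longer alkyl chain would fare at this place also stays open.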